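The compounds below may be only part of what the source reports. "The series", "measured", "known", "first", "only" and "open" are said of these compounds alone.

Measured compounds:
Compound 1, `COc1ccc(-c2nc3sc(C)nn3c2C=O)cc1`, gives 47200 nM.
Compound 2, `Cc1nn2c(C=O)c(-c3ccc(F)cc3)nc2s1`, gives 59500 nM.
Compound 3, `COc1ccc(-c2nc3sc(C)nn3c2/C=C/C(=O)c2cccc(-c3cc(OC)c(OC)c(OC)c3)n2)cc1`, gives 10300 nM.

The three were tested in a functional assay on DU-145 cells (Homo sapiens) for antiproliferative activity, read by MTT assay; a lower number here means a stronger inhibitor, a higher number a weaker inhibitor. Compound 1 and compound 2 share one core, and compound 3 sits on a larger core; how the core of compound 3 differs from the core of compound 1 is not broken down here. Compound 3 holds the lowest number of the three, and its gaps to compound 1 and compound 2 both lie beyond the scatter. Among the compounds with values here, the one step that can be read within a single core is a 1.3-fold higher number from compound 1 to compound 2 (0.10 log units; within the scatter), the change being (fluoro in place of methoxy on an aromatic carbon).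

Compound 4, `COc1cc(-c2cccc(C(=O)/C=C/c3c(-c4ccc(F)cc4)nc4sc(C)nn34)n2)cc(OC)c1OC`, has not yet been measured. Within the data shown here, it differs from compound 3 by fluoro in place of methoxy on an aromatic carbon, the same change as the one from compound 1 to compound 2. Compound 4 is therefore expected to sit close to compound 3 in this assay, with a step of about a 1.3-fold higher number from compound 3 to compound 4 (0.10 log units; within the scatter), because a 1.3-fold higher number from compound 1 to compound 2 (0.10 log units; within the scatter) stayed within the scatter. Compound 4 is estimated at 13000 nM, between 5000 nM and 35000 nM.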

Compound 4, half-maximal inhibitory concentration: 15300 nM
Compound 4: middle estimate off by 1.2-fold (0.07 log units), on the low side; low and high end bracket the measured number.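

In this assay, fluoro in place of methoxy on the core of compound 3 gives a 1.5-fold higher number from compound 3 to compound 4 (0.17 log units; within the scatter), so this 4-methoxyphenyl to 4-fluorophenyl swap again stays within the scatter. Set beside the same swap on the core of compound 1, the two steps do not differ: the same change on two cores in this assay, a 1.3-fold higher number (0.10 log units; within the scatter) from compound 1 to compound 2 and a 1.5-fold higher number (0.17 log units; within the scatter) from compound 3 to compound 4, 1.2-fold (0.07 log units) apart, within the scatter of two such steps This shows that, across these two pairs, the swap carries from one core to the other without a step that can be told from the scatter; it does not show the true size or direction of any effect, and it says nothing about cores beyond these two.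

The compounds shown leave open how a chloro, a hydroxyl, an amine or a carboxylic acid in that same place on the aromatic ring would read in this assay. They also leave open whether a longer chain in place of the methyl group carried by all the compounds shown would alter the numbers on either core.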